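A few compounds are considered here, and "the series" means these few. Any claim that something is new, unique, unknown or untested is made for them only; others in the source may bear on it.

Working notes on the series, read in a functional assay on A2780 cells (Homo sapiens) for antiproliferative activity, read by MTT assay, with a stated time of 48 h; a lower number here means a stronger inhibitor, a higher number a weaker inhibitor. Compound 1 (`COc1ccc(C(=O)c2cc(OC)c(OC)c(OC)c2)c(NC(=O)CO)c1`) gives 100 nM, compound 2 (`C=C(c1ccc(OC)cc1NC(=O)CO)c1ccc(OC)c2c1C=CC(C)(C)O2`) gives 280 nM, and compound 3 (`C=C(c1ccc2c(c1)C=CC(C)(C)O2)c1ccc(OC)cc1NC(=O)CO`) gives 110 nM. Compound 3 holds the second highest of these numbers: it lies within the scatter of compound 1 and beyond the scatter below compound 2.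

Compound 4 (`C=C(c1ccc2c(c1)C=CC(C)(C)O2)c1ccc(OC)cc1NC(=O)CN(C)C`) has dimethylamino in place of hydroxy on a saturated chain carbon bound to a carbonyl carbon. Among the measured compounds shown here, no measured pair shows this change, so the expectation in this assay is no step beyond the scatter, with a slight drift to a higher number at most. The expected step is a 1.4-fold higher number from compound 3 to compound 4 (0.13 log units; within the scatter). Compound 4 is estimated at 150 nM, with an expected range of 50 nM to 500 nM.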

Compound 4, half-maximal inhibitory concentration: 510 nM
The estimate for compound 4 lay 3.4-fold (0.53 log units) below the measured number; measured number outside the range, above it.
By their numbers in this assay, from the lowest: compounds 1 and 3 (each within the scatter of the next); then compounds 2 and 4 (each within the scatter of the next).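

In this assay, among the compounds shown here, dimethylamino in place of hydroxy on a saturated chain carbon bound to a carbonyl carbon gives a 4.6-fold higher number from compound 3 to compound 4 (0.67 log units; beyond the scatter), so this place does not take the change without loss, which the earlier compounds, all carrying hydroxy there, could not show. This single pair cannot separate the loss of hydroxy from the arrival of dimethylamino. No measurement here accounts for the step.

On these data alone, whether the step is specific to dimethylamino stays open. A primary amine, methoxy or a longer hydroxyalkyl chain at this place would help separate these readings.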